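Adding a Methoxy Group to a Paw-Edema Series

The source may hold more compounds than are shown below. What is called first, only, known or untested is meant among the compounds shown, and "the series" means these compounds.

Measured so far in a functional assay on the whole organism (strain Wistar albino) for inhibition, with Rattus norvegicus as the target, read by paw edema, with stated times of 1 h and 2 h, at a dose of 0.32 mmol/kg by the intraperitoneal route; a lower number here means less inhibition, a higher number more inhibition at the dose given (going by the name of the read-out):
Compound 1 `Cc1ccc(-c2nn(-c3ccc(Cl)cc3)cc2/C=N\c2ccccc2)cc1` gives 40.1%.
Compound 2 `COc1ccc(/N=C\c2cn(-c3ccc(Cl)cc3)nc2-c2ccc(C)cc2)cc1` gives 62%.
Compound 3 `COc1ccc(-c2nn(-c3ccc(Cl)cc3)cc2/C=N\c2ccccc2)cc1` gives 57.2%.

Compound 4 `COc1ccc(/N=C\c2cn(-c3ccc(Cl)cc3)nc2-c2ccc(OC)cc2)cc1` has not yet been measured. It differs from compound 3 by methoxy in place of hydrogen on an aromatic carbon. The same change has already been made once, from compound 1 to compound 2, where it reads methoxy in place of hydrogen on an aromatic carbon and brought a number 21.9 percentage points higher from compound 1 to compound 2 (beyond the scatter). The place of the change is described in the same words in both cases, so this is the same change carried out on a different core. The two cores differ as methoxy in place of methyl on an aromatic carbon, a change that on its own gave a number 17.1 percentage points higher from compound 1 to compound 3 (beyond the scatter). Compound 2 and compound 3 lie within the usual scatter of each other, so no order between them can be read.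

If the methoxy step repeats, the expected step is a number 15.8 percentage points higher from compound 3 to compound 4 (beyond the scatter), a little smaller than the earlier one, since compound 3 already begins at 57.2%, a higher number than compound 1 started from. Compound 4 is therefore expected to give about 73% in this assay, most likely between 60% and 85%.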

Compound 4, a percentage reported as inhibition, in the whole organism at one dose (the size of the read-out at that dose, not a potency): 69.2%
Compound 4: middle estimate off by 3.8 percentage points, on the high side; measured number inside the range.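

In this assay, going from phenyl to 4-methoxyphenyl on the core of compound 3 brought a number 12 percentage points higher from compound 3 to compound 4 (beyond the scatter), so the change kept its direction on a second core, and the two step sizes cannot be told apart: the same change on two cores in this assay, a number 21.9 percentage points higher (beyond the scatter) from compound 1 to compound 2 and a number 12 percentage points higher (beyond the scatter) from compound 3 to compound 4, 9.9 percentage points apart, within the scatter of two such steps

Methoxy in place of methyl gave a number 7.2 percentage points higher from compound 2 to compound 4 (within the scatter), so no order between those two compounds can be read, and this step also cannot be told apart from its earlier counterpart: the same change on two cores in this assay, a number 17.1 percentage points higher (beyond the scatter) from compound 1 to compound 3 and a number 7.2 percentage points higher (within the scatter) from compound 2 to compound 4, 9.9 percentage points apart, within the scatter of two such steps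

Two pairs of closely related compounds do not show that the steps would hold on other cores, and readings at a single dose give the size of the effect, not a potency.

The compounds shown carry only hydrogen, methyl or methoxy in the places that vary. Going by these compounds, how a hydroxyl group, an amine or a longer chain such as ethoxy would read in those places remains open.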